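Moving both chlorines on the hydrazone aryl ring

The source may hold more compounds than are shown below. What is called first, only, known or untested is meant among the compounds shown, and "the series" means these compounds.

Compound 1 `CN(C)CCn1cnnc1-c1cc(Oc2ccc(NC(=O)N/N=C/c3ccc(Cl)cc3)cc2F)ccn1` is the stronger of the two measured compounds in a functional assay on HT-29 cells (Homo sapiens) for cytotoxicity, read by MTT assay, with a stated time of 72 h (on this read-out higher numbers stand for weaker inhibition and lower numbers for stronger inhibition), where compound 1 gives 530 nM. Compound 2 `CN(C)CCn1cnnc1-c1cc(Oc2ccc(NC(=O)N/N=C/c3ccc(O)c(O)c3)cc2F)ccn1` gives 1890 nM in this assay, the change being a 3.6-fold higher number from compound 1 to compound 2 (0.55 log units; beyond the scatter). Compound 3 `CN(C)CCn1cnnc1-c1cc(Oc2ccc(NC(=O)N/N=C/c3c(Cl)cccc3Cl)cc2F)ccn1` differs from compound 1 in one place: 2,6-dichlorophenyl in place of 4-chlorophenyl on a carbon with a double bond to nitrogen. For the measured compounds named here, no measured step swaps one chlorinated ring for another; the only step at this position, from compound 1 to compound 2, exchanged 4-chlorophenyl for 3,4-dihydroxyphenyl and cost only a modest amount. A small step is therefore expected, a 1.4-fold higher number from compound 1 to compound 3 (0.15 log units; within the scatter), so compound 3 is estimated at 750 nM, between 250 nM and 2300 nM.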

Compound 3, half-maximal inhibitory concentration: 280 nM
The estimate for compound 3 lay 2.7-fold (0.43 log units) above the measured number; the measured number falls inside the stated range.
By their numbers in this assay, from the lowest: compounds 3 and 1 (each within the scatter of the next); then compound 2.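

In this assay, 2,6-dichlorophenyl in place of 4-chlorophenyl gives a 1.9-fold lower number from compound 1 to compound 3 (0.28 log units; within the scatter) and so leaves these two chlorinated rings indistinguishable on this read-out. In place of 3,4-dihydroxyphenyl, the same 2,6-dichlorophenyl gives a 6.8-fold lower number from compound 2 to compound 3 (0.83 log units; beyond the scatter) and so sets compound 2 apart from both chlorinated compounds, compound 1 and compound 3. No measurement available here explains either step.

From the compounds shown here alone, what a plain phenyl ring would give on this carbon remains open. So does the outcome for a ring carrying a methoxy group or an amine.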